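A Methyl on the Fused Core: Compound 4 in Prospect

The compounds below may be only part of what the source reports. "The series", "measured", "known", "first", "only" and "open" are said of these compounds alone.

Compound 2 `Cc1cccc(-c2ccc3cccnc3n2)c1` holds the highest number of the three measured compounds in a functional assay on CHO cells for antagonist activity at metabotropic glutamate receptor 5 (Rattus norvegicus), read by calcium flux (on this read-out higher numbers stand for weaker inhibition and lower numbers for stronger inhibition), where compound 2 gives 225 nM. Compound 1 `N#Cc1cccc(-c2ccc3cccnc3n2)c1` gives 115 nM, and the step of a 2.0-fold higher number from compound 1 to compound 2 (0.29 log units; within the scatter) stays within the scatter, so the two cannot be told apart on this read-out. Compound 3 `Cc1ccc(-c2ccc3cccnc3n2)cc1C` gives 45 nM, and the step of a 5.0-fold lower number from compound 2 to compound 3 (0.70 log units; beyond the scatter) lies beyond the scatter.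

Compound 4 `Cc1cccc(-c2ccc3ccc(C)nc3n2)c1` differs from compound 2 by methyl in place of hydrogen on an aromatic carbon. Neither measured step touches this ring. The step from compound 2 to compound 3 added a methyl, and lowered the number modestly, but on the ring that carries the cyano of compound 1; the step from compound 1 to compound 2 swapped groups on that same ring and stayed within the scatter. For the measured compounds named here, the data therefore carry no direct precedent for a methyl on the fused core, and a methyl added elsewhere gave only a modest gain in compound 3.

On this footing the writer expects, for compound 2 to compound 4, a step of a 1.3-fold lower number from compound 2 to compound 4 (0.10 log units; within the scatter) that stays within the scatter. For compound 4 the estimate is 180 nM, with a range from 60 nM to 550 nM.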

Compound 4, half-maximal inhibitory concentration: 277 nM
For compound 4 the middle estimate is 1.5-fold (0.19 log units) below the measured one; the range from low to high includes it.
By their numbers in this assay, from the lowest: compound 3; then compounds 1, 2 and 4 (each within the scatter of the next, the first and the last beyond it).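

In this assay, a methyl in place of hydrogen on an aromatic carbon of the six-membered aromatic ring with 1 nitrogen, next to the ring nitrogen, gives a 1.2-fold higher number from compound 2 to compound 4 (0.09 log units; within the scatter), so this position of the fused system tolerates the added methyl without a step that can be read apart from the scatter. The same kind of exchange on the other ring gave a 5.0-fold lower number from compound 2 to compound 3 (0.70 log units; beyond the scatter), so among the compounds shown, a methyl in place of hydrogen does not give one outcome wherever it is placed: compound 3 moves beyond the scatter and compound 4 does not. Nothing at hand accounts for this difference between the two positions.

The compounds shown leave open whether a group other than methyl at this carbon next to the ring nitrogen, such as an amine, a methoxy group or a longer chain, would move the number beyond the scatter. They also leave open how a methyl on the other carbons of this ring would read, since this one position is the only place on the fused system that has been varied here.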